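Replacing the ring group on compound 3's carbonyl

This account rests on a few compounds, and the source may have more. Where it says the series, first, only, none or still open, it means among the compounds named here.

- compound 1 `CC(C)C1=C(C(=O)N2[C@H](C)CC[C@H]2C(=O)N2CCN(C)CC2)SC2=N[C@@](C)(c3ccc(Cl)cc3)[C@@H](c3ccc(Cl)cc3)N21`: 190 nM
- compound 2 `CC(=O)N1CCN(C(=O)[C@@H]2CC[C@@H](C)N2C(=O)C2=C(C(C)C)N3C(=N[C@@](C)(c4ccc(Cl)cc4)[C@H]3c3ccc(Cl)cc3)S2)CC1`: 270 nM
- compound 3 `CC(=O)N1CCN(C(=O)[C@@H]2CC[C@@H](C)N2C(=O)C2=C(C(C)C)N3C(=N[C@@](C)(c4ccc(Cl)cc4)[C@H]3c3ccc(Cl)cc3)S2)C[C@H]1C`: 83 nM

In a functional assay on MV4-11 cells (Homo sapiens) for inhibition, read by luminescence, with a stated time of 3 days (a higher number here means a weaker inhibitor of growth, a lower number a stronger inhibitor of growth), compound 3 has the lowest number of the three, at 83 nM, and its gaps to the other two lie beyond the scatter. Compound 4 `CC(C)C1=C(C(=O)N2[C@H](C)CC[C@H]2C(=O)N2CCN(C)C(C)(C)C2)SC2=N[C@@](C)(c3ccc(Cl)cc3)[C@@H](c3ccc(Cl)cc3)N21` has not yet been measured. It differs from compound 3 by a group of 9 heavy atoms (7 carbon, 2 nitrogen; one six-membered non-aromatic ring with 2 hetero atoms) in place of a group of 10 heavy atoms (7 carbon, 2 nitrogen, 1 oxygen; one six-membered non-aromatic ring with 2 hetero atoms), on a carbonyl carbon, on a carbonyl carbon.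

For the measured compounds named here, two measured steps bear on this change. Acetyl in place of methyl gave a 1.4-fold higher number from compound 1 to compound 2 (0.15 log units; within the scatter), so that swap alone has shown no clear effect. Methyl in place of hydrogen on a saturated ring carbon gave a 3.3-fold lower number from compound 2 to compound 3 (0.51 log units; beyond the scatter), a modest step. Compound 4 has methyl where compound 3 has acetyl, and it keeps ring methyl as compound 3 does. Going by the values given here, no measured step combines these features, so the expectation is loose. A step beyond the scatter in this assay is not expected, and the expected change is a 1.2-fold higher number from compound 3 to compound 4 (0.08 log units; within the scatter). Compound 4 is estimated at 100 nM, with an expected range of 40 nM to 250 nM.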

Compound 4, concentration for 50% growth inhibition: 280 nM
Beside the measured number, compound 4's estimate is 2.8-fold (0.45 log units) below it; measured number above the stated range.
By their numbers in this assay, from the lowest: compound 3; then compounds 1, 2 and 4 (each within the scatter of the next).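

In this assay the low number of compound 3 does not survive this replacement: a 3.4-fold higher number from compound 3 to compound 4 (0.53 log units; beyond the scatter), so the choice of ring group on the carbonyl carbon matters here. Compound 4 is not separated from the compounds without a ring methyl, with a 1.0-fold higher number from compound 2 to compound 4 (0.02 log units; within the scatter) and a 1.5-fold higher number from compound 1 to compound 4 (0.17 log units; within the scatter). Among these four compounds, then, the gain from adding ring methyl appears only with acetyl on the ring nitrogen, in compound 3, and does not appear in compound 4, which has methyl there.

No measurement shown explains this difference. On these data alone, it remains open whether another group in place of acetyl, such as propanoyl or methylsulfonyl, would keep a number as low as that of compound 3.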